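Amino in Place of Chloro: From Compound 3 to Compound 4

A few compounds are considered here, and "the series" means these few. Any claim that something is new, unique, unknown or untested is made for them only; others in the source may bear on it.

Compound 3 `CCn1cc(-c2nc3ccc(Cl)cc3[nH]2)c(=O)c2cc(F)c(N3CCNCC3)cc21` gives the lowest of the three numbers in a functional assay on Bel-7402 cells (Homo sapiens) for cytotoxicity, read by MTT assay, with a stated time of 48 h (a higher number here means a weaker inhibitor, a lower number a stronger inhibitor), with 2800 nM in that assay. Compound 2 `CCn1cc(-c2nc3ccccc3o2)c(=O)c2cc(F)c(N3CCNC(C)C3)c(F)c21` gives 5700 nM and compound 1 `CCn1cc(-c2nc3ccccc3[nH]2)c(=O)c2cc(F)c(N3CCNCC3)cc21` gives 27400 nM in the same run of tests. Compound 4 `CCn1cc(-c2nc3ccc(N)cc3[nH]2)c(=O)c2cc(F)c(N3CCNCC3)cc21` differs from compound 3 by amino in place of chloro on an aromatic carbon on the shared core. Among the compounds with values here, the only measured step at this place is a 9.8-fold lower number from compound 1 to compound 3 (0.99 log units; beyond the scatter) and no measured compound carries amino there, so the amino itself is untested. Taking the chloro away is expected to give back part of that step, so a modest rise in this assay is expected for compound 4 (a 3.9-fold higher number from compound 3 to compound 4 (0.59 log units; beyond the scatter)). Compound 4 is therefore estimated at 11000 nM within a range from 3000 nM to 40000 nM in this assay.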

Compound 4, half-maximal inhibitory concentration: 92100 nM
Compound 4: the middle estimate sits 8.4-fold (0.92 log units) below what was measured, and the stated range ends below it.
By their numbers in this assay, from the lowest: compound 3; then compound 2; then compound 1; then compound 4.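

In this assay amino in place of chloro gives a 33-fold higher number from compound 3 to compound 4 (1.52 log units; beyond the scatter) and amino in place of hydrogen gives a 3.4-fold higher number from compound 1 to compound 4 (0.53 log units; beyond the scatter) so amino does not return the number to the level of hydrogen but passes it. This one position thus moves the number both ways on the shared core, down with chloro and up with amino. Nothing available explains this reversal. Going by these compounds, whether a bromo, a methoxy or a carboxylic acid here would side with chloro or with amino stays open. On these data alone, whether an acetylated amino would keep the rise also stays open.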